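Pyridin-2-yl against phenyl on two pyrazole and triazole cores

The compounds below may be only part of what the source reports. "The series", "measured", "known", "first", "only" and "open" are said of these compounds alone.

In an assay on MCF7 cells for inhibition of Serine-protein kinase ATM (Homo sapiens), read by immunofluorescence, with a stated time of 1 h (on this read-out higher numbers stand for weaker inhibition and lower numbers for stronger inhibition), compound 1 `Nc1nc(-c2ccccc2)nn1-c1ncnc2ccccc12` gives > 40000 nM, which is a limit of the assay and not a number. Compound 2 `Nc1nc(-c2ccccn2)nn1-c1ncnc2ccccc12` likewise gives > 40000 nM in this assay, again a limit. The change between them, (phenyl in place of pyridin-2-yl on an aromatic carbon), therefore gives a step that the two limits leave unreadable from compound 2 to compound 1; both ends sit at the limit of > 40000 nM in this assay, at which 2 of the 3 values shown sit. Going by the values given here, compound 3 `COc1cc2ncnc(-n3nc(-c4ccccn4)cc3N)c2cc1OC` is the one compound with a number here, giving 1600 nM in this assay. The difference between the core of compound 3 and that of compound 2 is not broken down here. Compound 4 `COc1cc2ncnc(-n3nc(-c4ccccc4)cc3N)c2cc1OC` is not yet measured. It differs from compound 3 by phenyl in place of pyridin-2-yl on an aromatic carbon, the same kind of change as that from compound 2 to compound 1, but the place is not the same: in compound 4 the ring is a five-membered aromatic ring with 2 nitrogen and the carbon is next to the ring nitrogen, whereas in compound 1 it is a ring with 3 nitrogen and the carbon is between two ring nitrogen atoms. The earlier step gives no readable size, so the expectation rests on compound 3 at 1600 nM alone. Compound 4 is expected to give a step of a 2.5-fold higher number from compound 3 to compound 4 (0.40 log units; beyond the scatter), a modest loss. Compound 4 is thus estimated at 4000 nM, between 1200 nM and 20000 nM.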

Compound 4, half-maximal inhibitory concentration: 20600 nM
Compound 4: middle estimate off by 5.2-fold (0.71 log units), on the low side; measured number outside the range, above it.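

In this assay, phenyl in place of pyridin-2-yl on the five-membered aromatic ring with 2 nitrogen gives a 13-fold higher number from compound 3 to compound 4 (1.11 log units; beyond the scatter), so on this core the change costs a large part of the inhibition. The same change from compound 2 to compound 1 cannot be read, because both compounds stand at a limit of the assay and not at a number: the limit of > 40000 nM in this assay, at which 2 of the 4 values shown sit. The series therefore shows the size of this step on one core only, and it neither confirms nor rules out that a similar loss would occur on the core of compound 1, nor does it show what causes the loss.

The compounds shown leave open whether the ring nitrogen of pyridin-2-yl must sit where it does, which a group such as pyridin-3-yl or pyrimidin-2-yl at the same place would test. They also leave open how an amine or a morpholine on that ring would fare, and which of the differences between the two cores matters most.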